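This account rests on a few compounds, and the source may have more. Where it says the series, first, only, none or still open, it means among the compounds named here.

Measured so far in an ADME assay on RAW264.7 cells (Mus musculus) for cytotoxicity, read by WST assay; on this read-out higher numbers stand for lower toxicity in this test and lower numbers for higher toxicity in this test:
Compound 1 `O=C(c1ccc(CN2Cc3ccccc3S2(=O)=O)cc1)N1CCCCC1`: compound 1 gives > 100000 nM, a limit of the assay.
Compound 2 `CC(C)(C)OC(=O)N(Cc1ccco1)C(=O)c1ccc(CN2C(=O)c3ccccc3C2=O)cc1`: compound 2 gives > 100000 nM, a limit of the assay.
Compound 3 `O=C(NCc1ccco1)c1ccc(CN2C(=O)c3ccccc3C2=O)cc1`: compound 3 gives > 100000 nM, a limit of the assay.

Compound 2 stands at a limit in this assay, and the other two values shown are limits as well, so no number separates any of the three. Going by the values given here, the single measured change of one place, a step that the two limits leave unreadable from compound 2 to compound 3, cannot be read in size, since both of its ends sit at the limit. Compound 4 `CC(C)(C)OC(=O)N(Cc1ccco1)C(=O)c1ccc(Cn2oc3ccccc3c2=O)cc1` differs from compound 2 by a group of 10 heavy atoms (7 carbon, 1 nitrogen, 2 oxygen; one five-membered aromatic ring with 2 hetero atoms, one six-membered aromatic ring of carbon only) in place of a group of 11 heavy atoms (8 carbon, 1 nitrogen, 2 oxygen; one five-membered non-aromatic ring with 1 hetero atom, one six-membered aromatic ring of carbon only), on a saturated chain carbon bound to an aromatic carbon. Among the compounds with values here, no measured step covers this change; the only evidence that bears on it is the limit of > 100000 nM in this assay, at which 3 of the 3 values shown sit, where every value of the series so far sits. For compound 4 no step beyond the scatter is therefore expected in this assay. Compound 4 is expected to give 100000 nM, with a range from 40000 nM to 300000 nM. The expected step is a number no higher from compound 2 to compound 4 (the limit leaves the size open), most likely reported again as a limit.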

Compound 4, concentration lethal to 50% of the cells: > 100000 nM
Compound 4: only a limit was reported; the forecaster's own chance of this, stated with the estimate: 80%; the middle value sits exactly at the limit.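

No new step can be read from compound 4: like compound 2, it stands at a limit in this assay, so the step between them stays unreadable. The compounds shown leave open whether any change in this series gives a measurable value: the limit of > 100000 nM in this assay, at which 4 of the 4 values shown sit.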